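The source may report more compounds than this note shows. Statements on the series, on what has been measured and on what is new or still open speak of the compounds shown alone.

Compound 1 `Cc1ccc2oc(/C=C/[S+](C)[O-])cc(=O)c2c1`: 7000 nM
Compound 2 `C[S+]([O-])/C=C/c1cc(=O)c2ccccc2o1`: 8000 nM
Compound 3 `CC(C)CCOc1ccc2oc(/C=C/[S+](C)[O-])cc(=O)c2c1`: 4100 nM

These three compounds share one core and differ only in a single group on an aromatic carbon. In a functional assay on DLD-1 cells (Homo sapiens) for cytotoxicity, with a stated time of 48 h (a higher number here means a weaker inhibitor, a lower number a stronger inhibitor), compound 3 gives the lowest of the three numbers, but its position is not a real lead: the step of a 1.7-fold lower number from compound 1 to compound 3 (0.23 log units; within the scatter) and the step of a 2.0-fold lower number from compound 2 to compound 3 (0.29 log units; within the scatter) both lie within the scatter, as does a 1.1-fold higher number from compound 1 to compound 2 (0.06 log units; within the scatter). So far, swapping the group at this position has not moved the number beyond what repeated measurements would show on their own.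

Compound 4 `C[S+]([O-])/C=C/c1cc(=O)c2cc(OC(=O)C(C)(C)C)ccc2o1` is the next candidate. It differs from compound 3 in one place: (tert-butyl)carbonyl in place of isopentyl on an oxygen on an aromatic ring. Going by the values given here, no measured pair shows a (tert-butyl)carbonyl entering on this oxygen, so the only guidance is that the three swaps made at this position so far all stayed within the scatter. For compound 4 the expected step is a 1.3-fold higher number from compound 3 to compound 4 (0.13 log units; within the scatter), again within the scatter. For compound 4 the estimate in this assay is 5500 nM, with a range from 2500 nM to 12000 nM.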

Compound 4, half-maximal inhibitory concentration: 8000 nM
For compound 4 the middle estimate is 1.5-fold (0.16 log units) below the measured one, and the stated range covers the measured number.
By their numbers in this assay, from the lowest: compounds 3, 1, 2 and 4 (each within the scatter of the next).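

Swapping isopentyl for (tert-butyl)carbonyl on the oxygen brings in a carbonyl, with one hydrogen-bond acceptor where the isopentyl had none, yet in this assay the result is a 2.0-fold higher number from compound 3 to compound 4 (0.29 log units; within the scatter) and so no real shift. The comparisons with the smaller groups agree, with no change at the digits printed from compound 2 to compound 4 (within the scatter) and a 1.1-fold higher number from compound 1 to compound 4 (0.06 log units; within the scatter), so even this change in the kind of group, and not only in its size, leaves all four compounds within the scatter of one another. Nothing available explains this flat picture.

On these data alone, whether any group at this place can move the number beyond the scatter remains open, for example an amine, a carboxylic acid or a longer chain on the oxygen. As far as these compounds go, all four compounds also share the same core, so the effect of changes elsewhere on it is unknown.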